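A chloro step from compound 1 to compound 3

A few compounds are considered here, and "the series" means these few. Any claim that something is new, unique, unknown or untested is made for them only; others in the source may bear on it.

Within the data shown here, in a functional assay on HeLa cells (Homo sapiens) for cytotoxicity, read by sulforhodamine B assay, with a stated time of 48 h (on this read-out higher numbers stand for weaker inhibition and lower numbers for stronger inhibition), compound 1 `O=C(c1cccnc1)c1ccccc1O` gives 33000 nM as one of only two measured values. The other comes from compound 2 `O=C(c1cccnc1)c1cc(Cl)ccc1O` at 24000 nM in the same read-out, and the two lie within the usual scatter of each other. Compound 3 `O=C(c1cccnc1)c1cccc(Cl)c1O` is still unmeasured. It carries chloro in place of hydrogen on an aromatic carbon of the core of compound 1, ortho to a hydroxy group (chloro in place of hydrogen on an aromatic carbon). Among the measured compounds shown here, the one measured step bearing on this is the same swap at a different place on the core (a 1.4-fold lower number from compound 1 to compound 2 (0.14 log units; within the scatter)), and it stays within the scatter. One step is thin evidence, but it gives no reason to expect a change beyond the scatter in this assay here. The expected step is a 1.3-fold lower number from compound 1 to compound 3 (0.12 log units; within the scatter) and should stay within the scatter. For compound 3 the estimated value is 25000 nM with an expected range of 11000 nM to 55000 nM as its likely span.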

Compound 3, half-maximal inhibitory concentration: 21000 nM
For compound 3 the middle estimate is 1.2-fold (0.08 log units) above the measured one; the range from low to high includes it.
By their numbers in this assay, from the lowest: compounds 3, 2 and 1 (each within the scatter of the next).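

In this assay, chloro on the aromatic carbon ortho to a hydroxy group gives a 1.6-fold lower number from compound 1 to compound 3 (0.20 log units; within the scatter). This adds a second place on the core of compound 1 where the swap of hydrogen for chloro stays within the scatter, so the result seen with compound 2 is not limited to a single position. No measurement at hand accounts for how little the number moves at this position.

Chloro is the only group shown here, so it remains open whether an amine, a carboxylic acid or a longer chain such as propyl in the same place would move the number beyond the scatter. It also remains open whether any change to the shared core can do so in this assay, since all the compounds shown lie within the scatter of their neighbours.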